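Adding a Phenoxy End to the Butyl Chain

A few compounds are considered here, and "the series" means these few. Any claim that something is new, unique, unknown or untested is made for them only; others in the source may bear on it.

In a functional assay on PC-3 cells (Homo sapiens) for antiproliferative activity, read by MTT assay, with a stated time of 48 h (a higher number here means a weaker inhibitor of growth, a lower number a stronger inhibitor of growth), compound 3 `CCCCN(Cc1ccc(C(=O)NO)cc1)c1ncc(-c2ccc(C)cc2)s1` gives 6410 nM, compound 1 `Cc1ccc(-c2cnc(N(CCCCOc3ccccc3)Cc3ccc(C(=O)NO)cc3)s2)cc1` gives 10300 nM, and compound 2 `Cc1ccc(OCCCCN(Cc2ccc(C(=O)NO)cc2)c2ncc(-c3ccc(C)cc3)s2)cc1` gives 1220 nM. That places the butyl compound close to one neighbour and apart from the other: the data show a 1.6-fold lower number from compound 1 to compound 3 (0.21 log units; within the scatter), and a 5.3-fold higher number from compound 2 to compound 3 (0.72 log units; beyond the scatter). Compound 4 `Cc1ccc(-c2cnc(N(CCCOc3ccccc3)Cc3ccc(C(=O)NO)cc3)s2)cc1` brings (phenoxy in place of methyl on a saturated chain carbon, three bonds along the chain from a nitrogen on an aromatic ring), phenoxy in place of methyl, reading butyl to 3-phenoxypropyl. The nearest evidence is a 1.6-fold lower number from compound 1 to compound 3 (0.21 log units; within the scatter), where plain phenoxy sits four bonds along the chain rather than three. The larger 8.4-fold lower number from compound 1 to compound 2 (0.93 log units; beyond the scatter) needs a methyl that compound 4 lacks. Among the measured compounds shown here, no measured step tests the shorter chain, so only a small rise in this assay is expected, with the estimate being a 1.2-fold higher number from compound 3 to compound 4 (0.10 log units; within the scatter). For compound 4 the estimated value is 8000 nM, within a range of 3000 nM to 20000 nM.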

Compound 4, concentration for 50% growth inhibition: 17500 nM
Beside the measured number, compound 4's estimate is 2.2-fold (0.34 log units) below it; the measured number falls inside the stated range.
By their numbers in this assay, from the lowest: compound 2; then compounds 3, 1 and 4 (each within the scatter of the next, the first and the last beyond it).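

In this assay, 3-phenoxypropyl in place of butyl gives a real loss of growth inhibition (a 2.7-fold higher number from compound 3 to compound 4 (0.44 log units; beyond the scatter)), while shortening the chain that carries plain phenoxy stays within the scatter (a 1.7-fold higher number from compound 1 to compound 4 (0.23 log units; within the scatter)). The largest gap lies with the 4-methylphenoxy compound (a 14-fold higher number from compound 2 to compound 4 (1.16 log units; beyond the scatter)), though that step changes both the chain and the methyl. No measurement shown here offers an explanation for these differences. Still open, as far as these compounds go, is whether 4-methylphenoxy would help on the 3-phenoxypropyl chain, and how a longer chain or an amine at the chain end would behave.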